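The source may hold more compounds than are shown below. What is called first, only, known or untested is meant among the compounds shown, and "the series" means these compounds.

Measured compounds:
Compound 1 `O=C1O/C(=C\Cn2cc(-c3ccc(Br)cc3)nn2)C(OCc2ccccc2)=C1OCc1ccccc1` in a functional assay on A549 cells (Homo sapiens) for antiproliferative activity, read by MTT assay, with a stated time of 72 h (a higher number here means a weaker inhibitor, a lower number a stronger inhibitor), gives > 100000 nM, a limit of the assay rather than a number.
Compound 2 `CCCCCc1ccc(-c2cn(C/C=C3\OC(=O)C(OCc4ccccc4)=C3OCc3ccccc3)nn2)cc1` in this assay gives > 100000 nM, again only a limit.
Compound 3 `COc1ccccc1-c1cn(C/C=C2\OC(=O)C(OCc3ccccc3)=C2OCc2ccccc2)nn1` in this assay gives > 100000 nM, also a limit.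

All three share one core and differ only in the group on the five-membered ring. The steps a step that the two limits leave unreadable from compound 1 to compound 2, a step that the two limits leave unreadable from compound 1 to compound 3 and a step that the two limits leave unreadable from compound 2 to compound 3 cannot be sized because of the limit of > 100000 nM in this assay, at which 3 of the 3 values shown sit. Compound 3 thus stands at that limit, without a number of its own. Compound 4 `O=C1O/C(=C\Cn2cc(-c3cccc(O)c3)nn2)C(OCc2ccccc2)=C1OCc1ccccc1` differs from it in one place: 3-hydroxyphenyl in place of 2-methoxyphenyl on an aromatic carbon. Among the measured compounds shown here, no measured step separates a 3-hydroxyphenyl from a 2-methoxyphenyl, so the expected step of a number no higher from compound 3 to compound 4 (the limit leaves the size open) has no readable size or direction. The estimate is that compound 4 again reaches only the limit, at 100000 nM, between 30000 nM and 300000 nM.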

Compound 4, half-maximal inhibitory concentration: 23300 nM
The estimate for compound 4 lay 4.3-fold (0.63 log units) above the measured number; the measured number lies below the stated range.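

Changing the group on the five-membered aromatic ring can bring the shared core off the limit in this assay. Putting 3-hydroxyphenyl in place of 2-methoxyphenyl gives an at least 4.2-fold lower number from compound 3 to compound 4 (0.63 log units; beyond the scatter), while the swaps for 4-pentylphenyl and 4-bromophenyl give an at least 4.2-fold lower number from compound 2 to compound 4 (0.63 log units; beyond the scatter) and an at least 4.2-fold lower number from compound 1 to compound 4 (0.63 log units; beyond the scatter). Each of these steps starts from a limit, so each gives only a minimum size.

As far as these compounds go, it remains open whether the change in activity follows the hydroxyl group itself or its place on the phenyl ring. Also open, from the compounds shown here alone, is how a phenyl ring carrying an amine or a carboxylic acid would behave here.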